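Swapping an Open Chain for a Five-Membered Ring

The compounds below may be only part of what the source reports. "The series", "measured", "known", "first", "only" and "open" are said of these compounds alone.

Compound 1 `Clc1ccc(Nc2nccs2)cc1OCc1ccoc1` and compound 2 `CC/C(C)=C\COc1cc(Nc2nccs2)ccc1Cl` share a core and differ only in the group on a saturated chain carbon bound to an oxygen on an aromatic ring. In a functional assay on MT2 cells (Homo sapiens) for cytotoxicity, read by MTT assay (on this read-out higher numbers stand for lower toxicity in this test and lower numbers for higher toxicity in this test), compound 1 gives 26000 nM and compound 2 gives 18000 nM, a value within the scatter of the first, so the two stand level.

The next structure is compound 3 `CC1=C(COc2cc(Nc3nccs3)ccc2Cl)CCC1`, in which 2-methylcyclopent-1-en-1-yl replaces 2-methylbut-1-en-1-yl: 2-methylcyclopent-1-en-1-yl in place of 2-methylbut-1-en-1-yl on a saturated chain carbon bound to an oxygen on an aromatic ring.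

Among the measured compounds shown here, only one measured step bears on this change. It sits at the same place, with 2-methylbut-1-en-1-yl in place of furan-3-yl, and amounts to a 1.4-fold lower number from compound 1 to compound 2 (0.16 log units; within the scatter). For the measured compounds named here, that is a single small step, and no measured compound yet carries 2-methylcyclopent-1-en-1-yl, so the evidence is thin. On this evidence, no step beyond the scatter is expected in this assay. The estimated step is no change at the digits printed from compound 2 to compound 3 (within the scatter). Compound 3 is expected to give about 18000 nM, with an estimated range of 9000 nM to 36000 nM.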

Compound 3, half-maximal cytotoxic concentration: 11000 nM
Beside the measured number, compound 3's estimate is 1.6-fold (0.21 log units) above it; the range from low to high includes it.
By their numbers in this assay, from the lowest: compounds 3, 2 and 1 (each within the scatter of the next, the first and the last beyond it).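

Closing the open chain into a ring changes little at this place: in this assay, 2-methylcyclopent-1-en-1-yl in place of 2-methylbut-1-en-1-yl gives a 1.6-fold lower number from compound 2 to compound 3 (0.21 log units; within the scatter), so compound 2 and compound 3 stand level. Among the compounds shown here, the new finding is the first step at this position to pass the scatter, a 2.4-fold lower number from compound 1 to compound 3 (0.37 log units; beyond the scatter), with 2-methylcyclopent-1-en-1-yl in place of furan-3-yl, which shows that the group on this saturated chain carbon can shift the read-out modestly towards higher toxicity in this test, while compound 2 lies within the scatter of both neighbours and only the two ends of the series can be told apart. Nothing available here explains this modest shift.

Going by these compounds, it remains open whether an amine or a carboxylic acid on the same saturated chain carbon would move the number further than these groups, all of which have no hydrogen-bond donors, and whether a plain cyclopentyl ring without the double bond would read like 2-methylcyclopent-1-en-1-yl. On these data alone, it is also open whether the step from furan-3-yl would hold on a core other than the shared one.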